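Sulfonyl anilides: phenyl for methyl on the sulfonamide nitrogen

This account rests on a few compounds, and the source may have more. Where it says the series, first, only, none or still open, it means among the compounds named here.

Measured so far:
compound 1 `Cc1cccc(S(=O)(=O)c2ccc(NC(=O)C(C)(O)C(F)(F)F)cc2)c1`: 2200 nM in a functional assay (Cavia porcellus) with sulfonylurea receptors; K-ATP channels (Homo sapiens) as the target; on this read-out lower numbers stand for stronger inhibition and higher numbers for weaker inhibition
compound 2 `CN(c1ccccc1)S(=O)(=O)c1ccc(NC(=O)C(C)(O)C(F)(F)F)cc1`: 2000 nM in this assay

Among the compounds with values here, compound 2 holds the lowest of the two numbers, yet the only measured step, a 1.1-fold lower number from compound 1 to compound 2 (0.04 log units; within the scatter), lies within the scatter, so the two compounds are not separated on this read-out. Compound 3 `CC(O)(C(=O)Nc1ccc(S(=O)(=O)N(c2ccccc2)c2ccccc2)cc1)C(F)(F)F` is the next member: phenyl in place of methyl on a sulfonamide nitrogen. Within the data shown here, no measured step touches the sulfonamide nitrogen; the one known step concerns the group on the sulfonyl sulfur, and it was flat. The series therefore gives no ground for expecting a shift beyond the scatter, and the estimate rests on compound 2 alone. Compound 3 is expected to give about 2000 nM, with a range from 700 nM to 6000 nM. The expected step is no change at the digits printed from compound 2 to compound 3 (within the scatter), a change of no real size.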

Compound 3, half-maximal inhibitory concentration: > 30000 nM
Compound 3 gave a limit, no number (the forecaster's own chance of this, stated with the estimate: 5%); middle value at least 15-fold (1.17 log units) from the limit.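

In this assay, within the data shown here, phenyl in place of methyl on a sulfonamide nitrogen gives an at least 15-fold higher number from compound 2 to compound 3 (1.17 log units; beyond the scatter), the first step beyond the scatter. The earlier step, a 1.1-fold lower number from compound 1 to compound 2 (0.04 log units; within the scatter), concerned the group on the sulfonyl sulfur and showed no separation, so the read-out's flatness there says nothing about this nitrogen, where one change of group is enough to move it. Compound 3 stands at a limit of the assay and not at a number, so the full size of the step stays unknown: the limit of > 30000 nM in this assay, at which 1 of the 3 values shown sits.

Only methyl and phenyl are shown on this nitrogen, so it remains open how the read-out behaves between them. A hydrogen, an ethyl or a benzyl at that place would show whether any group larger than methyl is enough for the shift or whether it is specific to the phenyl ring.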